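Phthalimide-triazole thioethers: cytotoxicity on A549 cells

A few compounds are considered here, and "the series" means these few. Any claim that something is new, unique, unknown or untested is made for them only; others in the source may bear on it.

Compound 1, `Cc1nnc(SCc2ccccc2)n1N1C(=O)c2ccccc2C1=O`, gives in a functional assay on A549 cells (Homo sapiens) for cytotoxicity, read by MTT assay, with a stated time of 48 h (on this read-out higher numbers stand for weaker inhibition and lower numbers for stronger inhibition), only the limit > 200000 nM.
Compound 2, `Cc1nnc(SCC(=O)c2ccc(Cl)cc2)n1N1C(=O)c2ccccc2C1=O`, gives in this assay only the limit > 200000 nM.
Compound 3, `CCCc1nnc(SCc2ccccc2)n1N1C(=O)c2ccccc2C1=O`, gives in this assay only the limit > 200000 nM.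

Compound 4, `CCCc1nnc(SCC(=O)c2ccc(Cl)cc2)n1N1C(=O)c2ccccc2C1=O`, is not yet measured. It differs from compound 3 by (4-chlorophenyl)carbonyl in place of phenyl on a saturated chain carbon bound to a sulfur. The same change is made from compound 1 to compound 2, ((4-chlorophenyl)carbonyl in place of phenyl on a saturated chain carbon bound to a sulfur), where the step is a step that the two limits leave unreadable from compound 1 to compound 2. The two cores differ by ethyl in place of hydrogen on a saturated chain carbon bound to an aromatic carbon, and that step is a step that the two limits leave unreadable from compound 1 to compound 3. All three measured values sit at the limit of > 200000 nM in this assay, at which 3 of the 3 values shown sit, so no step can be read in size. Compound 4 is therefore expected to give a limit as well, with an estimate of 250000 nM, between 100000 nM and 600000 nM, and the expected step that the limit leaves unreadable from compound 3 to compound 4 is flat.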

Compound 4, half-maximal inhibitory concentration: > 200000 nM
Compound 4 was reported as a limit; the forecaster's own chance of this, stated with the estimate: 85%; the middle value does not contradict the limit.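

Neither step to compound 4, from compound 3 or from compound 2, can be read, as compound 4 gives only a limit, like compound 1, compound 2 and compound 3: the limit of > 200000 nM in this assay, at which 4 of the 4 values shown sit. The compounds shown leave open whether either change has any effect, and how large it would be.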